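Swapping a Trifluoromethoxy Anchor for a Benzyloxy Tail

This account rests on a few compounds, and the source may have more. Where it says the series, first, only, none or still open, it means among the compounds named here.

Of the compounds shown here, three sharing one core have been tested in a physicochemical assay for solubility, read by HPLC, at pH 7; on this read-out lower numbers stand for lower solubility and higher numbers for higher solubility. Compound 1 `O=[N+]([O-])c1cn2c(n1)OC[C@@H](OCC#Cc1ccc(OC(F)(F)F)cc1)C2` gives 0.77 ug/mL; compound 3 `O=[N+]([O-])c1cn2c(n1)OC[C@@H](OCC#Cc1cccc(-c3ccc(OC(F)(F)F)cc3)c1)C2` gives 0.27 ug/mL, and compound 2 `O=[N+]([O-])c1cn2c(n1)OC[C@@H](OCCOc1ncc(-c3ccc(OC(F)(F)F)cc3)cn1)C2` gives 21 ug/mL. Compound 1 therefore sits in the middle of the three: its gap to compound 3 and its much larger gap to compound 2 both exceed the usual scatter of this assay.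

Compound 4 `O=[N+]([O-])c1cn2c(n1)OC[C@@H](OCC#Cc1ccc(OCc3ccccc3)cc1)C2` has not yet been measured. It differs from compound 1 in one place: benzyl in place of trifluoromethyl on an oxygen on an aromatic ring. Read one bond further out, the change is trifluoromethoxy to benzyloxy, adding one six-membered aromatic ring of carbon only. Among the measured compounds shown here, no comparable step among the measured compounds exists, so the expectation rests on compound 1 alone. A modest downward step of about a 1.9-fold lower number from compound 1 to compound 4 (0.28 log units; within the scatter) is expected, giving compound 4 an estimated 0.4 ug/mL in this assay, within a range of 0.1 ug/mL to 1.5 ug/mL.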

Compound 4, solubility: 0.43 ug/mL
Compound 4: middle estimate off by 1.1-fold (0.03 log units), on the low side, and the stated range covers the measured number.
By their numbers in this assay, from the lowest: compounds 3, 4 and 1 (each within the scatter of the next, the first and the last beyond it); then compound 2.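

In this assay, the first change shown at this oxygen gives a 1.8-fold lower number from compound 1 to compound 4 (0.25 log units; within the scatter). Benzyl brings 7 heavy atoms and one six-membered aromatic ring of carbon only, where trifluoromethyl had 4 heavy atoms and no ring, yet this larger group leaves compound 1 and compound 4 indistinguishable on this read-out. No data shown here offer an explanation for this result.

As far as these compounds go, whether an amine or a carboxylic acid on this oxygen would give a step beyond the scatter remains open. So does whether benzyl would give a similar result in the side chains of compound 2 and compound 3.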